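The source may report more compounds than this note shows. Statements on the series, on what has been measured and on what is new or still open speak of the compounds shown alone.

Measured so far:
Compound 1 `CCCCCCCCCCc1ccc(-c2noc(CCCN(C)C)n2)cc1`: 8%
Compound 2 `CCCCCCCCCCc1ccc(-c2noc(CN3CCNCC3)n2)cc1`: 19%

In an assay on HeLa cells for inhibition of sphingosine-1-phosphate transporter SPNS2 (Mus musculus), read by LC-MS, tested at 2 uM (on this read-out higher numbers stand for more inhibition at the one concentration tested (going by the name of the read-out) and lower numbers for less inhibition), compound 1 gives 8%, and compound 2 gives 19%. Among the compounds with values here, compound 2 stands highest of the two numbers; its only neighbour is compound 1, and the step was a number 11 percentage points higher from compound 1 to compound 2 (beyond the scatter).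

Compound 3 `CCCCCCCCCCc1ccc(-c2noc([C@@H](N)CCCCN)n2)cc1` has not yet been measured in this assay. Relative to compound 2 the change is 1,5-diaminopentyl in place of (piperazin-1-yl)methyl on an aromatic carbon. So the side chain on the shared core is again exchanged, this time for an open chain carrying two amines.

Within the data shown here, the one measured step, a number 11 percentage points higher from compound 1 to compound 2 (beyond the scatter), is the only guide: it shows that swapping the amine-bearing side chain at this carbon of the core can shift inhibition by a modest amount, upward in that case. From the compounds shown here alone, whether a second amine-bearing chain shifts it further is unknown, and both measured numbers are low, so a small upward step or none beyond the scatter seems most likely. Compound 3 is therefore estimated to give 24%, somewhere between 5% and 48%. This estimate means a step of a number 5 percentage points higher from compound 2 to compound 3 (within the scatter).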

Compound 3, a percentage reported as inhibition, at one concentration (the size of the read-out at that concentration, not a potency): 43%
The estimate for compound 3 lay 19 percentage points below the measured number; the measured number falls inside the stated range.
By their numbers in this assay, from the lowest: compound 1; then compound 2; then compound 3.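

Swapping (piperazin-1-yl)methyl for 1,5-diaminopentyl on the shared core gives a number 24 percentage points higher from compound 2 to compound 3 (beyond the scatter) in this assay, even though both groups hold 7 heavy atoms, 5 carbon and 2 nitrogen. So at this position it is not only which atoms are present that counts, but also how they are arranged: here as an open chain, not a six-membered ring. Measured against the 3-(dimethylamino)propyl group, the same 1,5-diaminopentyl group gives a bigger change, a number 35 percentage points higher from compound 1 to compound 3 (beyond the scatter), and nothing measured alongside these numbers accounts for either rise.

The step from compound 2 to compound 3 removes the ring and brings in a defined stereocentre at the same time, so the compounds shown leave open which of these two changes matters, or whether both do. The mirror-image form of the 1,5-diaminopentyl group would address the stereocentre, while a shorter 1,4-diaminobutyl chain, a longer 1,6-diaminohexyl chain or a carboxylic acid in place of one amine would test how much the chain length and each amine contribute.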